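The source may hold more compounds than are shown below. What is called first, only, known or untested is meant among the compounds shown, and "the series" means these compounds.

Measured so far: compound 1 `CCCCCc1ccc(-c2cn(C[C@H](O)[C@H]3OC(=O)C(OCc4ccccc4)=C3OCc3ccccc3)nn2)cc1` gives 13800 nM in a functional assay on HCT-116 cells (Homo sapiens) for antiproliferative activity, read by MTT assay, with a stated time of 72 h; on this read-out lower numbers stand for stronger inhibition and higher numbers for weaker inhibition; compound 2 `C[Si](C)(C)c1cn(C[C@H](O)[C@H]2OC(=O)C(OCc3ccccc3)=C2OCc2ccccc2)nn1` gives 31800 nM.

Compound 2 stands as the highest of the two numbers, with compound 1 nearest at a 2.3-fold higher number from compound 1 to compound 2 (0.36 log units; beyond the scatter). Compound 3 `Cc1ccc(S(=O)(=O)NCc2cn(C[C@H](O)[C@H]3OC(=O)C(OCc4ccccc4)=C3OCc3ccccc3)nn2)cc1` differs from compound 2 by a group of 12 heavy atoms (8 carbon, 1 nitrogen, 2 oxygen, 1 sulfur; one six-membered aromatic ring of carbon only) in place of a group of 4 heavy atoms (3 carbon, 1 silicon; no ring), on an aromatic carbon. Within the data shown here, the single step that bears on this exchange, a 2.3-fold higher number from compound 1 to compound 2 (0.36 log units; beyond the scatter), shows that a larger ring-bearing group at the same position gave the lower number, so a modest drop is expected here. Compound 3 is therefore estimated at 20000 nM, within 8000 nM to 50000 nM, a step of a 1.6-fold lower number from compound 2 to compound 3 (0.20 log units; within the scatter).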

Compound 3, half-maximal inhibitory concentration: 13100 nM
For compound 3 the middle estimate is 1.5-fold (0.18 log units) above the measured one; the range from low to high includes it.
By their numbers in this assay, from the lowest: compounds 3 and 1 (each within the scatter of the next); then compound 2.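

In this assay, putting (((4-methylphenyl)sulfonyl)amino)methyl on this aromatic carbon gives a 2.4-fold lower number from compound 2 to compound 3 (0.39 log units; beyond the scatter) beyond the scatter, so a second large, ring-bearing group, quite different in its atoms, also reads lower than the silicon-bearing group. Exchanging 4-pentylphenyl for it gives a 1.1-fold lower number from compound 1 to compound 3 (0.02 log units; within the scatter) and stays within the scatter, so these two unlike groups cannot be told apart here. No evidence is available that explains these results. Still open, as far as these compounds go, is how a plain methyl, an amine or a carboxylic acid on this carbon would read.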